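This account rests on a few compounds, and the source may have more. Where it says the series, first, only, none or still open, it means among the compounds named here.

Measured so far:
compound 1 `COc1ccc(C2CC(c3ccccc3)=NN2C2=NC(=O)/C(=C3\C(=O)Nc4ccccc43)S2)cc1` gives 20800 nM
compound 2 `COc1ccc(C2CC(c3ccccc3)=NN2C2=NC(=O)/C(=C3\C(=O)Nc4ccc(Br)cc43)S2)cc1` gives 4230 nM

In a functional assay on cells (Leukemia cell, Homo sapiens) for cytotoxicity, read by sulforhodamine B assay, with a stated time of 48 h (a higher number here means a weaker inhibitor of growth, a lower number a stronger inhibitor of growth), compound 1 stands as the higher of the two numbers; its nearest neighbour is compound 2, reached by a 4.9-fold lower number from compound 1 to compound 2 (0.69 log units; beyond the scatter), a change made on the aromatic carbon of the shared core and not on the pyrazoline ring.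

Compound 3 `COc1ccc(C2CC(c3ccc4ccccc4c3)=NN2C2=NC(=O)/C(=C3\C(=O)Nc4ccccc43)S2)cc1` differs from compound 1 by naphthalen-2-yl in place of phenyl on a carbon with a double bond to nitrogen. Within the data shown here, no measured step touches this position: the only step known alters a different part of the core, so it offers no direct guide to the size or direction of the change in this assay. Compound 3 is therefore expected to sit close to compound 1, with at most a small shift, and the estimated step is a 1.7-fold lower number from compound 1 to compound 3 (0.24 log units; within the scatter). The estimate for compound 3 is 12000 nM, with a range from 5000 nM to 40000 nM.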

Compound 3, concentration for total growth inhibition: 59600 nM
Compound 3: middle estimate off by 5.0-fold (0.70 log units), on the low side; measured number above the stated range.
By their numbers in this assay, from the lowest: compound 2; then compound 1; then compound 3.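

In this assay, this carbon with a double bond to nitrogen proves sensitive to its aryl group: naphthalen-2-yl in place of phenyl, which adds a second six-membered aromatic ring, gives a 2.9-fold higher number from compound 1 to compound 3 (0.46 log units; beyond the scatter), so growth inhibition weakens. Among these compounds, the only earlier step, a 4.9-fold lower number from compound 1 to compound 2 (0.69 log units; beyond the scatter), lay elsewhere on the shared core and ran the other way, so the two sites on compound 1 respond in opposite directions to the changes tried so far. Nothing available explains why the second aromatic ring has this effect.

The compounds shown leave open how a methyl group, a methoxy-substituted phenyl or a pyridine ring would read at this carbon. They also leave open whether the bromo step would hold alongside naphthalen-2-yl, as no compound shown carries both changes.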